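The source may hold more compounds than are shown below. What is called first, only, known or untested is meant among the compounds shown, and "the series" means these compounds.

Compounds measured in a physicochemical assay for solubility; a higher number here means a more soluble compound, a lower number a less soluble compound:
- compound 1 `O=S(=O)(Nc1ncccn1)c1ccc2c(c1)OCC[C@@H]2c1ccc(C(F)(F)F)cc1-c1ccc(F)nc1`: 408000 nM
- compound 2 `Cc1nc(-c2cc(C(F)(F)F)ccc2[C@H]2CCOc3cc(S(=O)(=O)Nc4cccc(F)n4)ccc32)co1`: 13000 nM

Of these two, compound 2 has the lower number at 13000 nM, and the gap to compound 1 lies beyond the scatter. The next compound, compound 3 `Cc1nc(-c2cc(C(F)(F)F)ccc2[C@H]2CCOc3cc(S(=O)(=O)Nc4ncc(F)cn4)ccc32)co1`, departs from compound 2 in one place, on a sulfonamide nitrogen: 5-fluoropyrimidin-2-yl in place of 6-fluoropyridin-2-yl on a sulfonamide nitrogen. Among the compounds with values here, no measured pair shows this change alone, so the forecast in this assay is uncertain. The high number of compound 1, 408000 nM, leans the expectation upward. A moderate rise beyond the scatter is expected, estimated as a 3.1-fold higher number from compound 2 to compound 3 (0.49 log units; beyond the scatter). For compound 3 the estimated value is 40000 nM, with an expected range of 12000 nM to 150000 nM.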

Compound 3, solubility: 281000 nM
The estimate for compound 3 lay 7.0-fold (0.85 log units) below the measured number; measured number above the stated range.
By their numbers in this assay, from the lowest: compound 2; then compounds 3 and 1 (each within the scatter of the next).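

In this assay, 5-fluoropyrimidin-2-yl in place of 6-fluoropyridin-2-yl on the sulfonamide nitrogen gives a 22-fold higher number from compound 2 to compound 3 (1.33 log units; beyond the scatter). This shows that this position alone can carry a large step, with the heavy-atom count of the group unchanged. No evidence at hand accounts for the step.

The step swaps a ring carbon for a nitrogen and also moves the fluorine, and the compounds shown do not separate the two. A 5-fluoropyridin-2-yl group at the same place would bear on that question.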